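Aryl group variation on the carbonyl carbon

The source may hold more compounds than are shown below. What is called first, only, known or untested is meant among the compounds shown, and "the series" means these compounds.

Measured compounds:
compound 1 `COc1ccc(-c2cc3ccccc3nc2/C=C/C(=O)c2ccc(F)cc2)cc1` — a functional assay on NCI-H1299 cells (Homo sapiens) for antiproliferative activity, read by XTT assay, with a stated time of 72 h; a lower number here means a stronger inhibitor, a higher number a weaker inhibitor: 820 nM
compound 2 `COc1ccc(-c2cc3ccccc3nc2/C=C/C(=O)c2ccc(O)cc2)cc1` — 8970 nM
compound 3 `COc1ccc(-c2cc3ccccc3nc2/C=C/C(=O)c2c(OC)cccc2OC)cc1` — 4710 nM

Compound 3 sits second highest of the three numbers. Its nearest neighbour is compound 2, the step of a 1.9-fold lower number from compound 2 to compound 3 (0.28 log units; within the scatter); its furthest is compound 1, the step of a 5.7-fold higher number from compound 1 to compound 3 (0.76 log units; beyond the scatter).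

Compound 4 `COc1ccc(-c2cc3ccccc3nc2/C=C/C(=O)c2ccc(N)cc2)cc1` differs from compound 3 in one place: 4-aminophenyl in place of 2,6-dimethoxyphenyl on a carbonyl carbon. Among the compounds with values here, two measured steps bear on this position. The exchange of 4-fluorophenyl for 2,6-dimethoxyphenyl gave a 5.7-fold higher number from compound 1 to compound 3 (0.76 log units; beyond the scatter), and the exchange of 4-hydroxyphenyl for 2,6-dimethoxyphenyl gave a 1.9-fold lower number from compound 2 to compound 3 (0.28 log units; within the scatter). The 4-aminophenyl group, like the 4-hydroxyphenyl group of compound 2, brings one hydrogen-bond donor to the same place, so compound 2 is the closer guide, and its value was within the scatter of compound 3. For compound 4 the step of a 1.3-fold higher number from compound 3 to compound 4 (0.11 log units; within the scatter) is therefore expected to stay within the scatter. Compound 4 is estimated at 6000 nM, within a range from 2000 nM to 20000 nM.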

Compound 4, half-maximal inhibitory concentration: 6510 nM
Compound 4: middle estimate off by 1.1-fold (0.04 log units), on the low side; low and high end bracket the measured number.
By their numbers in this assay, from the lowest: compound 1; then compounds 3, 4 and 2 (each within the scatter of the next).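

In this assay the 4-aminophenyl group of compound 4 cannot be told apart from the two weaker aryl groups: the step of a 1.4-fold higher number from compound 3 to compound 4 (0.14 log units; within the scatter) and the step of a 1.4-fold lower number from compound 2 to compound 4 (0.14 log units; within the scatter) both stay within the scatter. Amino in place of fluoro gives a 7.9-fold higher number from compound 1 to compound 4 (0.90 log units; beyond the scatter), beyond the scatter, so of the four aryl groups on the carbonyl carbon only the 4-fluorophenyl group of compound 1 stands apart. The hydrogen-bond donor that enters with the 4-aminophenyl group does not separate compound 4 from compound 3 in this assay. No evidence at hand accounts for these results.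

Whether the separation of compound 1 is particular to fluoro remains open, since a 4-chlorophenyl or an unsubstituted phenyl group on the same carbonyl carbon is not among the compounds shown. A 4-carboxyphenyl group would also test how far the three grouped compounds represent other substituents.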